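Notes on the step from compound 3 to compound 4

The source may report more compounds than this note shows. Statements on the series, on what has been measured and on what is new or still open speak of the compounds shown alone.

Compound 3 `CC(=O)N1N=C(c2cc3ccccc3nc2C)CC1c1ccc([N+](=O)[O-])cc1` stands at the limit in an ADME assay on A549 cells (Homo sapiens) for cytotoxicity, read by MTT assay, with a stated time of 48 h; a lower number here means a stronger inhibitor, a higher number a weaker inhibitor: compound 3 gives > 200 ug/mL, a limit rather than a number. Compound 1 `CC(=O)N1N=C(c2cc3ccccc3nc2C)CC1c1ccc(C#N)cc1` gives > 200 ug/mL, likewise a limit. Compound 2 `CC(=O)N1N=C(c2cc3ccccc3nc2C)CC1/C=C/c1ccccc1` gives 93.3 ug/mL. The measured steps are an at least 2.1-fold lower number from compound 1 to compound 2 (0.33 log units; beyond the scatter), an at least 2.1-fold higher number from compound 2 to compound 3 (0.33 log units; beyond the scatter) and a step that the two limits leave unreadable from compound 1 to compound 3; two of the three values rest at the limit of > 200 ug/mL in this assay, at which 2 of the 3 values shown sit. Compound 4 `CC(=O)N1N=C(c2cc3ccccc3nc2C)CC1c1ccc(Oc2nc(Cl)c(Cl)cc2Cl)cc1` differs from compound 3 by (3,5,6-trichloropyridin-2-yl)oxy in place of nitro on an aromatic carbon. Among the compounds with values here, no measured step swaps one group for another on this aromatic ring with a readable outcome, so the expectation rests on the limit of compound 3 alone. Compound 4 is therefore expected to move by an at least 1.3-fold lower number from compound 3 to compound 4 (0.12 log units; that floor lies within the scatter), and its estimated value is 150 ug/mL.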

Compound 4, half-maximal inhibitory concentration: > 200 ug/mL
Compound 4: no number, only a limit; the forecaster's own chance of this, stated with the estimate: 50%; at least 1.3-fold (0.12 log units) between middle value and limit.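

In this assay, within the data shown here, compound 4 gives > 200 ug/mL as a limit, not a number, and no new step from compound 1 or compound 3 to compound 4 can be read. Open remains how the values of compound 1, compound 3 and compound 4 stand relative to one another.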